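Cytotoxicity notes on an amide series, compound 4 pending

A few compounds are considered here, and "the series" means these few. Any claim that something is new, unique, unknown or untested is made for them only; others in the source may bear on it.

Compound 1 `O=C(NCC1CCCCC1)c1cccc(/C=C2\CC(=O)N(c3ccccc3)C2=O)c1` in an ADME assay on NCM460 cells (Homo sapiens) for cytotoxicity, read by MTT assay, with a stated time of 72 h (a lower number here means a stronger inhibitor, a higher number a weaker inhibitor), gives > 100000 nM, a limit of the assay.
Compound 2 `CCc1cccc(NC(=O)c2cccc(/C=C3\CC(=O)N(Cc4ccccc4)C3=O)c2)c1` gives > 100000 nM, also a limit.
Compound 3 `CCCCCN1C(=O)C/C(=C\c2cccc(C(=O)Nc3cccc(CC)c3)c2)C1=O` gives > 100000 nM, again a limit.

Within the data shown here, compound 1 therefore stands at the limit of this assay and nowhere on a numbered scale; the limit of > 100000 nM in this assay, at which 3 of the 3 values shown sit, covers every value so far. Among the measured compounds shown here, the only step between two measured compounds, a step that the two limits leave unreadable from compound 2 to compound 3, cannot be sized and sits at another position. Compound 4 `O=C(Nc1ccc(F)cc1)c1cccc(/C=C2\CC(=O)N(c3ccccc3)C2=O)c1` differs from compound 1 by 4-fluorophenyl in place of cyclohexylmethyl on an amide-type nitrogen. For the measured compounds named here, no measured step bears on this change, so no direction can be read. With all three values at the limit, the step that the limit leaves unreadable from compound 1 to compound 4 is expected to be none beyond the scatter. Compound 4 is estimated at 150000 nM, with a range from 50000 nM to 500000 nM, and is expected to return a limit once more.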

Compound 4, half-maximal inhibitory concentration: > 100000 nM
Compound 4: a limit, no number (the forecaster's own chance of this, stated with the estimate: 85%); the middle value is on the limit's open side.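

Compound 1 and compound 4 both return limits, not numbers, so no new step can be read between them: the limit of > 100000 nM in this assay, at which 4 of the 4 values shown sit.

Left open is whether any change on the shared core would give a number rather than a limit.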